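From Nitro to Methyl on a Shared Core

This account rests on a few compounds, and the source may have more. Where it says the series, first, only, none or still open, it means among the compounds named here.

Measured in a functional assay on MDA-MB-231 cells (Homo sapiens) for cytotoxicity, read by MTT assay, with a stated time of 48 h; a higher number here means a weaker inhibitor, a lower number a stronger inhibitor:
- Compound 1 `O=C(O)CN1C(=O)/C(=C/c2nc3ccccc3n2Cc2ccc(Br)cc2)SC1=S`: 8720 nM
- Compound 2 `N#Cc1ccc(Cn2c(/C=C3\SC(=S)N(CC(=O)O)C3=O)nc3ccccc32)cc1`: 11200 nM
- Compound 3 `O=C(O)CN1C(=O)/C(=C/c2nc3ccccc3n2Cc2ccc([N+](=O)[O-])cc2)SC1=S`: 7760 nM

These three compounds differ only in bromo, cyano or nitro on an aromatic carbon. Compound 3 gives 7760 nM, which cannot be told apart from the other two values, since a 1.1-fold lower number from compound 1 to compound 3 (0.05 log units; within the scatter) and a 1.4-fold lower number from compound 2 to compound 3 (0.16 log units; within the scatter) both lie within the scatter.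

Compound 4 `Cc1ccc(Cn2c(/C=C3\SC(=S)N(CC(=O)O)C3=O)nc3ccccc32)cc1` has methyl in place of nitro on an aromatic carbon, para to a large group (methyl in place of nitro on an aromatic carbon). Going by the values given here, no measured compound carries methyl, so the evidence is indirect. It comes from the swaps at this same place, and the remaining one, a 1.3-fold higher number from compound 1 to compound 2 (0.11 log units; within the scatter), also lies within the scatter. Given those small steps to compound 2 and compound 3, no step beyond the scatter is expected in this assay. The estimate amounts to a 1.2-fold higher number from compound 3 to compound 4 (0.09 log units; within the scatter), an expected step that stays within the scatter. For compound 4 the estimated value is 9500 nM, with an expected range of 5000 nM to 18000 nM.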

Compound 4, half-maximal inhibitory concentration: 1040 nM
Estimate against measurement, compound 4: 9.1-fold (0.96 log units) above, outside the stated range (below it).
By their numbers in this assay, from the lowest: compound 4; then compounds 3, 1 and 2 (each within the scatter of the next).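

In this assay, the group at this position turns out to matter: methyl gives a 7.5-fold lower number from compound 3 to compound 4 (0.87 log units; beyond the scatter), an 8.4-fold lower number from compound 1 to compound 4 (0.92 log units; beyond the scatter) and an 11-fold lower number from compound 2 to compound 4 (1.03 log units; beyond the scatter), all beyond the scatter, even though bromo, cyano and nitro at this same carbon could not be told apart. The flat picture from compounds 1, 2 and 3 therefore holds only among those three groups, and it does not extend to methyl, which has 1 heavy atom and 0 hydrogen-bond acceptors where nitro has 3 heavy atoms and 2 hydrogen-bond acceptors. No measurement at hand gives a reason for this drop in the number.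

As far as these compounds go, whether the low number belongs to methyl alone stays open, since an ethyl group, a methoxy group or an amine at this carbon might or might not match it. Also open, from the compounds shown here alone, is how plain hydrogen at this carbon would compare.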